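Swapping one five-membered heteroaryl for another on the shared core

The source may hold more compounds than are shown below. What is called first, only, known or untested is meant among the compounds shown, and "the series" means these compounds.

Measured so far:
compound 1 `CCCC[S+]([O-])c1sc2nc(-c3nccs3)cc(-c3cnc(C)[nH]3)c2c1N` — 2.3 nM
compound 2 `CCCC[S+]([O-])c1sc2nc(-c3nccs3)cc(-c3cnc(Cl)n3C)c2c1N` — 3.2 nM

In an assay for inhibition of 15-hydroxyprostaglandin dehydrogenase [NAD(+)] (Homo sapiens), read by fluorescence, with a stated time of 15 min, in the presence of a further agent that is not named here (on this read-out lower numbers stand for stronger inhibition and higher numbers for weaker inhibition), compound 2 gives 3.2 nM, the highest of the two numbers, yet within the scatter of compound 1. Compound 3 `CCCC[S+]([O-])c1sc2nc(-c3nccs3)cc(-c3nccs3)c2c1N` differs from compound 2 in one place: 1,3-thiazol-2-yl in place of 2-chloro-1-methyl-1H-imidazol-5-yl on an aromatic carbon. For the measured compounds named here, the only comparable step, a 1.4-fold higher number from compound 1 to compound 2 (0.14 log units; within the scatter), altered the group on that same aromatic carbon without a change beyond the scatter. One step is thin evidence for a new group, so for compound 3 a step near zero is expected, a 1.3-fold higher number from compound 2 to compound 3 (0.10 log units; within the scatter), with the range widened for the unknown. The expected value for compound 3 is 4 nM, between 1.5 nM and 12 nM.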

Compound 3, half-maximal inhibitory concentration: 1.8 nM
For compound 3 the middle estimate is 2.2-fold (0.35 log units) above the measured one, and the stated range covers the measured number.
By their numbers in this assay, from the lowest: compounds 3, 1 and 2 (each within the scatter of the next).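

In this assay, the carbon opposite the ring nitrogen also accepts a 1,3-thiazol-2-yl group: the data show a 1.8-fold lower number from compound 2 to compound 3 (0.25 log units; within the scatter), and a 1.3-fold lower number from compound 1 to compound 3 (0.11 log units; within the scatter). Both steps stay within the scatter, so this ring, which contains sulfur and carries no methyl or chlorine, performs on a par with both substituted imidazoles. Nothing here explains why these three rings give such similar numbers. The compounds shown leave open whether this position would tolerate a six-membered ring such as phenyl or pyridyl, or a non-aromatic group such as an amine.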